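The source may hold more compounds than are shown below. What is called first, only, known or untested is meant among the compounds shown, and "the series" means these compounds.

In a functional assay on HepG2 cells (Homo sapiens) for antiproliferative activity, read by MTT assay, with a stated time of 72 h (on this read-out lower numbers stand for stronger inhibition and higher numbers for weaker inhibition), compound 1 `FC(F)(F)c1ccc(COc2cccc(Nc3ncnc4cc5c(cc34)OCCOCCOCCO5)c2)cc1` gives 34000 nM. Compound 2 `c1ccc(COc2cccc(Nc3ncnc4cc5c(cc34)OCCOCCOCCO5)c2)cc1` reaches only the limit of this assay, > 100000 nM, so for compound 2 no number is known. The measured step of an at least 2.9-fold higher number from compound 1 to compound 2 (0.46 log units; beyond the scatter) shows that replacing the trifluoromethyl with hydrogen weakens the compound, with compound 2 sitting at the limit of > 100000 nM in this assay, at which 1 of the 2 values shown sits. Compound 3 `O=[N+]([O-])c1ccc(COc2cccc(Nc3ncnc4cc5c(cc34)OCCOCCOCCO5)c2)cc1` differs from compound 2 by the change (nitro in place of hydrogen on an aromatic carbon), so a substituent again occupies the place that carried trifluoromethyl in compound 1 and is unoccupied in compound 2. Going by the values given here, only that single step bears on the change, and it is at least modest in size. The expectation is therefore that compound 3 moves back towards the region of compound 1, with an estimated step of an at least 2.5-fold lower number from compound 2 to compound 3 (0.39 log units; beyond the scatter) in this assay. Compound 3 is thus expected to give about 40000 nM, with a range from 12000 nM to 130000 nM, and a real chance that it too reaches only a limit.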

Compound 3, half-maximal inhibitory concentration: > 100000 nM
Compound 3 gave a limit, no number (the forecaster's own chance of this, stated with the estimate: 35%); middle value at least 2.5-fold (0.39 log units) from the limit.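

At this place on the aromatic ring, nitro does not serve as a substitute for trifluoromethyl: in this assay, the exchange gives an at least 2.9-fold higher number from compound 1 to compound 3 (0.46 log units; beyond the scatter). Occupying the position is therefore not enough in itself to reach the number seen for compound 1, and among the groups shown, only trifluoromethyl gives a measurable value. The step between compound 2 and compound 3 cannot be read, and hydrogen and nitro cannot be ranked, since both compounds stand at a limit: the limit of > 100000 nM in this assay, at which 2 of the 3 values shown sit.

On these data alone, it remains open how far compound 2 and compound 3 lie beyond that limit, and so whether nitro changes anything at all relative to hydrogen. As far as these compounds go, it also remains open whether another group at this place, such as chlorine, methoxy or an amine, would give a measurable number.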